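The compounds below may be only part of what the source reports. "The series", "measured", "known", "first", "only" and "open" are said of these compounds alone.

Compound 1 `CCOc1cc(C)cc2c1C(=O)C=CC2=O`: 25300 nM
Compound 2 `Cc1cc(O)c2c(c1Cl)C(=O)C=CC2=O`: 17200 nM

In a functional assay on SNO cells (Homo sapiens) for cytotoxicity, read by XTT assay, with a stated time of 24 h (a lower number here means a stronger inhibitor, a higher number a weaker inhibitor), compound 2 gives 17200 nM and compound 1 gives 25300 nM. Among the compounds with values here, these are the only two measured values, and they lie within the scatter of each other, so the data do not rank compound 2 against compound 1.

Compound 3 `CCOc1cc(C)c(Cl)c2c1C(=O)C=CC2=O` has not yet been measured. It departs from compound 2 by one change, ethyl in place of hydrogen on an oxygen on an aromatic ring, which turns hydroxy to ethoxy: ethyl in place of hydrogen on an oxygen on an aromatic ring. Within the data shown here, no measured pair isolates this change, so its size in this assay cannot be read directly. Compound 1 also carries ethoxy and gives 25300 nM, so no step beyond the scatter is expected. The estimated change is a 1.2-fold higher number from compound 2 to compound 3 (0.07 log units; within the scatter). For compound 3 the expected value is 20000 nM, with an estimated range from 8000 nM to 45000 nM.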

Compound 3, half-maximal inhibitory concentration: 44200 nM
Estimate against measurement, compound 3: 2.2-fold (0.34 log units) below, within the range that was stated.
By their numbers in this assay, from the lowest: compounds 2, 1 and 3 (each within the scatter of the next, the first and the last beyond it).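

In this assay, within the data shown here, ethyl in place of hydrogen on the oxygen on an aromatic ring, which turns hydroxy to ethoxy, gives the first step in this set that lies beyond the scatter, a 2.6-fold higher number from compound 2 to compound 3 (0.41 log units; beyond the scatter), so with the chloro group present this change goes with a modest loss of inhibition. Chloro in place of hydrogen on an aromatic carbon, read with ethoxy present, gives a 1.7-fold higher number from compound 1 to compound 3 (0.24 log units; within the scatter), which lies within the scatter, so that change shows no readable effect here. No measurement at hand gives a reason for either step.

The compounds shown leave open whether the ethoxy step also holds without the chloro group. They also leave open how a methoxy group, a longer chain such as butoxy, or an amine would read on the same position.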